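Truncating one alkyne arm of the bis-thioether compound 3

The source may hold more compounds than are shown below. What is called first, only, known or untested is meant among the compounds shown, and "the series" means these compounds.

Compound 3 `OCC#CCSc1cnc2ccccc2c1SCC#CCO` stands at the top of the numbers in a functional assay on SW707 cells (Homo sapiens) for cytotoxicity, read by sulforhodamine B assay, with a stated time of 72 h (a lower number here means a stronger inhibitor, a higher number a weaker inhibitor), where compound 3 gives 32 ug/mL. Its nearest neighbour is compound 2 `OCC#CCSc1cnc2ccccc2c1[Se]CC#CCO`, which gives 26.6 ug/mL; the step of a 1.2-fold higher number from compound 2 to compound 3 (0.08 log units; within the scatter) is within the scatter. Among the measured compounds shown here, the only compound set apart is compound 1 `OCC#CCSc1cnc2ccccc2c1[Se]CC#CCBr`, which gives 2.8 ug/mL, so that an 11-fold higher number from compound 1 to compound 3 (1.06 log units; beyond the scatter) and a 9.5-fold higher number from compound 1 to compound 2 (0.98 log units; beyond the scatter) are both beyond the scatter.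

Compound 4 `CSc1c(SCC#CCO)cnc2ccccc12` is derived from compound 3 by the change (hydrogen in place of 3-hydroxyprop-1-yn-1-yl on a saturated chain carbon bound to a sulfur); cut one bond further out, the same difference reads 4-hydroxybut-2-yn-1-yl to methyl. For the measured compounds named here, none of the measured steps touches this position: the two steps that are beyond the scatter both concern the bromo-bearing arm of compound 1, and the one step on the unchanged sulfur arm, a 1.2-fold higher number from compound 2 to compound 3 (0.08 log units; within the scatter), is within the scatter. Going by the values given here, there is therefore no precedent for shortening this chain, and the expectation for compound 4 in this assay rests on the weak end of the series only.

Compound 4 is expected to give about 35 ug/mL, within 15 ug/mL to 80 ug/mL, meaning an expected step of a 1.1-fold higher number from compound 3 to compound 4 (0.04 log units; within the scatter) that is estimated to stay near the scatter.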

Compound 4, concentration for 50% inhibition: 69.3 ug/mL
Beside the measured number, compound 4's estimate is 2.0-fold (0.30 log units) below it, within the range that was stated.
By their numbers in this assay, from the lowest: compound 1; then compounds 2 and 3 (each within the scatter of the next); then compound 4.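

In this assay, among the compounds shown here, hydrogen in place of 3-hydroxyprop-1-yn-1-yl on a saturated chain carbon bound to a sulfur gives a 2.2-fold higher number from compound 3 to compound 4 (0.34 log units; beyond the scatter) and is the first step at this position, so the chain here is not neutral to shortening down to methyl. Compound 4 is also set apart from the selenium-bearing compounds, with a 2.6-fold higher number from compound 2 to compound 4 (0.42 log units; beyond the scatter) and a 25-fold higher number from compound 1 to compound 4 (1.39 log units; beyond the scatter) on the aromatic carbon. Nothing measured here accounts for the size of these steps.

Going by these compounds, it remains open which part of the lost 3-hydroxyprop-1-yn-1-yl matters, the hydroxy or the triple bond, and whether an ethyl chain at this position would read like compound 3 or like compound 4. Also open, on these data alone, is whether a bromo or an amine at the end of this chain would move the number towards that of compound 1.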